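This account rests on a few compounds, and the source may have more. Where it says the series, first, only, none or still open, it means among the compounds named here.

Working notes on the series. In an ADME assay on HepG2 cells (Homo sapiens) for cytotoxicity, read by MTT assay, with a stated time of 72 h (a higher number here means that more compound is tolerated, a lower number that less compound is tolerated), compound 1 `COc1ccccc1C#Cc1cc(Cl)cn2c([N+](=O)[O-])c(CS(=O)(=O)c3ccccc3)nc12` gives > 3900 nM as a limit and not a number. Compound 2 `O=[N+]([O-])c1c(CS(=O)(=O)c2ccccc2)nc2c(C#Cc3ccc(F)cc3)cc(Cl)cn12` gives > 3900 nM as a limit too. Compound 3 `O=[N+]([O-])c1c(CS(=O)(=O)c2ccccc2)nc2c(C#Cc3ccccc3F)cc(Cl)cn12` gives > 3900 nM as a limit as well. Compound 3 thus stands at the limit of > 3900 nM in this assay, at which 3 of the 3 values shown sit, and has no number of its own.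

The next change is thiophen-2-yl in place of 2-fluorophenyl on a triple-bonded carbon and it leads to compound 4 `O=[N+]([O-])c1c(CS(=O)(=O)c2ccccc2)nc2c(C#Cc3cccs3)cc(Cl)cn12`. The core stays the same and only the group on the triple-bonded carbon is exchanged, now for thiophen-2-yl.

Within the data shown here, three measured steps bear on this, all of them changes in that same group. These are a step that the two limits leave unreadable from compound 1 to compound 2 and a step that the two limits leave unreadable from compound 1 to compound 3 and finally a step that the two limits leave unreadable from compound 2 to compound 3 as well. None of them has a readable size, so they give neither a size nor a direction to carry over. All three compounds nevertheless report the same limit, so no step beyond the scatter is expected for the exchange of one such group for another. The expected result in this assay is a step that the limit leaves unreadable from compound 3 to compound 4 with no direction favoured, and a report as a limit is the likeliest outcome.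

For compound 4 the estimate is 5000 nM with an expected range of 2500 nM to 10000 nM in this series.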

Compound 4, half-maximal cytotoxic concentration: > 3900 nM
Compound 4: a limit, no number; the forecaster's own chance of this, stated with the estimate: 80%; the middle value does not contradict the limit.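

In this assay compound 4 gives > 3900 nM, which is a limit and not a number. No step linking compound 4 to compound 1, compound 2 or compound 3 can be read, because all four report only this limit: the limit of > 3900 nM in this assay, at which 4 of the 4 values shown sit.

The compounds shown leave open where the half-maximal cytotoxic concentration of each lies, and whether exchanging the group on the triple-bonded carbon changes it at all.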